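This account rests on a few compounds, and the source may have more. Where it says the series, first, only, none or still open, it means among the compounds named here.

Working notes on the series.

Three compounds of the series have numbers in a functional assay on the whole organism (Tail, strain ICR) with Mus musculus as the target, in the tail flick test, with a stated time of 120 min, at a dose of 25 umol/kg by the oral route; a higher number here means a stronger effect of the compound at the dose given, a lower number a weaker effect. Compound 1, `NC(=O)CC[C@H](NC(=O)CN(c1ncnc2c1ncn2C1CCCCO1)C1CC1)C(=O)OCc1ccccc1`, gives 22.3% in this assay. Compound 2, `O=C(O)[C@@H]1CCCN1C(=O)CN(c1nc(Cl)nc2[nH]cnc12)C1CC1`, gives 23.6% in this assay. Compound 3, `O=C(CN(c1nc(Cl)nc2[nH]cnc12)C1CC1)N[C@@H](CC(=O)OCc1ccccc1)C(=O)OCc1ccccc1`, gives 12.1% in this assay. Compound 1 holds the second highest of the three numbers; its nearest neighbour is compound 2, whose number lies within the scatter of that of compound 1, so the two cannot be ordered. Its furthest neighbour is compound 3, whose number lies beyond the scatter and is the lower of the two.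

Compound 4, `C[C@H](NC(=O)CN(c1ncnc2c1ncn2C1CCCCO1)C1CC1)C(=O)OCc1ccccc1`, has not yet been measured in this assay. It differs from compound 1 in one place: hydrogen in place of carbamoylmethyl on a saturated chain carbon, two bonds along the chain from an amide-type nitrogen and a carbonyl carbon. For the measured compounds named here, no step between two measured compounds of this kind is on hand, so the size of the change is not known from the data. The three measured numbers all sit in a narrow band at this dose, and the change removes only a small side chain, so the step from compound 1 to compound 4 is expected to stay within the scatter: a number 2.3 percentage points lower from compound 1 to compound 4 (within the scatter) is the expected step. Compound 4 is therefore estimated to give about 20% in this assay, with a likely range from 8% to 32%.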

Compound 4, a percentage reported as activity, at one dose (the size of the read-out at that dose, not a potency): 25.3%
Compound 4: middle estimate off by 5.3 percentage points, on the low side; low and high end bracket the measured number.
By their numbers in this assay, from the lowest: compound 3; then compounds 1, 2 and 4 (each within the scatter of the next).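

For the compounds shown here, this is the first step that can be read at a single position. In this assay, hydrogen in place of carbamoylmethyl on a saturated chain carbon, two bonds along the chain from an amide-type nitrogen and a carbonyl carbon, amounts to a number 3 percentage points higher from compound 1 to compound 4 (within the scatter). The read-out at this dose therefore gives no sign that the carbamoylmethyl group is needed, as the whole group can be replaced without a step that can be told from the scatter, and this holds for this one pair on this one core. No measurement on hand bears on why the number stays within the scatter across this change.

Only carbamoylmethyl and hydrogen are shown at this carbon on this core, so it remains open whether a carboxylic acid, an amine or a longer chain such as a phenylethyl group there would give a step beyond the scatter. With a single dose and a single time point shown, it also remains open whether the same pair would stay this close at other doses or times.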